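Azole swap at the aryl terminus of a bombesin receptor subtype-3 series

This account rests on a few compounds, and the source may have more. Where it says the series, first, only, none or still open, it means among the compounds named here.

Measured so far in a functional assay on HEK293 cells for agonist activity at Bombesin receptor subtype-3 (Mus musculus), read by luminescence and calcium flux, with a stated time of 10 min; on this read-out lower numbers stand for an effect already at smaller amounts and higher numbers for an effect only at larger amounts of compound:
- compound 1 `c1ccc(-c2ccc(CCc3nc(CC4CCCC4)c[nH]3)cc2)nc1`: 22 nM
- compound 2 `CCC(C)(C)Cc1c[nH]c(CCc2ccc(-n3ncnn3)cc2)n1`: 25 nM
- compound 3 `O=C(O)c1cc(F)c(F)cc1-c1ccc(CCc2nc(CC3CCCCC3)c[nH]2)cc1`: 4.7 nM

Compound 2 carries the highest number of the three in this assay; its gap to compound 1 lies within the scatter, while compound 3 sits a clear distance lower. For the measured compounds named here, no single-change pair exists among the measured compounds, so no step has been established.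

Compound 4 `CCC(C)(C)Cc1c[nH]c(CCc2ccc(-n3cccn3)cc2)n1` differs from compound 2 in one place: 1H-pyrazol-1-yl in place of 2H-tetrazol-2-yl on an aromatic carbon. Both groups are five-membered aromatic rings with no net charge. Going by the values given here, with no measured step to lean on, the step from compound 2 to compound 4 is expected to stay within the scatter, no change at the digits printed from compound 2 to compound 4 (within the scatter), with no clear direction. Compound 4 is therefore estimated at 25 nM, with a range of 10 nM to 70 nM.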

Compound 4, half-maximal effective concentration: 9 nM
Estimate against measurement, compound 4: 2.8-fold (0.44 log units) above; measured number outside the range, below it.
By their numbers in this assay, from the lowest: compounds 3 and 4 (each within the scatter of the next); then compounds 1 and 2 (each within the scatter of the next).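

In this assay, for the compounds shown here, the step of a 2.8-fold lower number from compound 2 to compound 4 (0.44 log units; beyond the scatter) is the first single-change step and lies beyond the scatter. At this position, para to a large group, the two uncharged five-membered aromatic rings are therefore not interchangeable. Nothing on hand explains the step.

Going by these compounds, whether the number follows the count of ring nitrogens remains open, with only two azoles compared at this position; a 1H-imidazol-1-yl group there would add a further point. Also open, on these data alone, is whether the same swap gives a similar step with a different alkyl group on the core.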